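The compounds below may be only part of what the source reports. "The series", "measured", "known", "first", "only" and "open" are said of these compounds alone.

Measured so far:
- compound 1 `N#Cc1ccc(/C=C/S(=O)(=O)Cc2ccc(Nc3ncnc4ccccc34)cc2)cc1`: > 100000 nM
- compound 2 `O=S(=O)(/C=C/c1ccc(Cl)cc1)Cc1ccc(Nc2ncnc3ccccc23)cc1`: 73000 nM
- compound 3 `O=S(=O)(/C=C/c1ccc(F)cc1F)Cc1ccc(Nc2ncnc3ccccc23)cc1`: > 100000 nM

All three were tested in a functional assay on HT-29 cells (Homo sapiens); on this read-out lower numbers stand for stronger inhibition of growth and higher numbers for weaker inhibition of growth. Compound 3 gives > 100000 nM, which is a limit of the assay and not a number. Compound 1 gives > 100000 nM, which is also a limit. Going by the values given here, compound 2 gives 73000 nM, the only true number so far.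

Compound 4 `O=S(=O)(/C=C/c1ccc(F)cc1Cl)Cc1ccc(Nc2ncnc3ccccc23)cc1` differs from compound 3 in one place: chloro in place of fluoro on an aromatic carbon. This puts chloro in place of fluoro on an aromatic carbon, ortho to a large group and meta to a fluoro group.

Among the compounds with values here, two measured steps bear on this change. Chloro in place of cyano gave an at least 1.3-fold lower number from compound 1 to compound 2 (0.13 log units; that floor lies within the scatter), and 2,4-difluorophenyl in place of 4-chlorophenyl gave an at least 1.3-fold higher number from compound 2 to compound 3 (0.13 log units; that floor lies within the scatter). Both involve 4-chlorophenyl, whereas compound 4 carries 2-chloro-4-fluorophenyl. Little size can be read from them because of the limit of > 100000 nM in this assay, at which 2 of the 3 values shown sit. No step beyond the scatter is therefore expected in this assay, and compound 4 may well return only a limit.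

The expected step is an at least 1.1-fold lower number from compound 3 to compound 4 (0.04 log units; that floor lies within the scatter).

Compound 4 is estimated at 90000 nM, with an expected range of 45000 nM to 180000 nM.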

Compound 4, concentration for 50% growth inhibition: 100000 nM
For compound 4 the middle estimate is 1.1-fold (0.05 log units) below the measured one; measured number inside the range.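

In this assay, compound 4 gives 100000 nM, a true number rather than a limit, which gives a number no higher from compound 3 to compound 4 (the limit leaves the size open) and a number no higher from compound 1 to compound 4 (the limit leaves the size open), so a ring carrying chloro ortho to a large group now has a readable value on this read-out. Going by these compounds alone, the one step that can be read is a 1.4-fold higher number from compound 2 to compound 4 (0.14 log units; within the scatter), so 2-chloro-4-fluorophenyl and 4-chlorophenyl do not separate here, and adding this chloro to the fluoro-bearing ring brings no clear gain in growth inhibition. The size of the other two steps cannot be read, and the change from fluoro to chloro at this position therefore stays without a size, because the measurable range ends right where these compounds fall: the limit of > 100000 nM in this assay, at which 2 of the 4 values shown sit.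

What the compounds shown leave open is whether any group at this position can bring the number down by more than the scatter, for example an amine, a methoxy group or a carboxylic acid in place of the chloro. They also leave open whether a change elsewhere, such as a longer chain in place of the 2-(2-chloro-4-fluorophenyl)ethenyl group, would lift this series clear of the limit, where differences could then be given a size.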